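The source may report more compounds than this note shows. Statements on the series, on what has been measured and on what is new or still open speak of the compounds shown alone.

Compound 1 `Cn1cc(C2CC(c3ccccc3)=NN2C(=O)c2cccnc2)c2cc(Br)ccc21` and compound 2 `Cn1cc(C2CC(c3ccc(F)cc3)=NN2C(=O)c2cccnc2)c2cc(Br)ccc21` are built on the same core, and compound 2 carries the change (fluoro in place of hydrogen on an aromatic carbon). In a functional assay on A549 cells (Homo sapiens) for inhibition, read by MTT assay, with a stated time of 48 h (on this read-out higher numbers stand for weaker inhibition of growth and lower numbers for stronger inhibition of growth), compound 1 gives 1600 nM, while compound 2 gives 1380 nM, so the step of a 1.2-fold lower number from compound 1 to compound 2 (0.06 log units; within the scatter). Compound 3 `COc1ccc2c(c1)c(C1CC(c3ccccc3)=NN1C(=O)c1ccc(OC)nc1)cn2C` rests on a different core; the difference between the two cores is not broken down here. In this assay compound 3 gives 1110 nM. Compound 4 `COc1ccc2c(c1)c(C1CC(c3ccc(F)cc3)=NN1C(=O)c1ccc(OC)nc1)cn2C`, not yet measured, differs from compound 3 by fluoro in place of hydrogen on an aromatic carbon, the same change at the same place as before. Because the earlier step of a 1.2-fold lower number from compound 1 to compound 2 (0.06 log units; within the scatter) stayed within the scatter, the expected step of a 1.2-fold lower number from compound 3 to compound 4 (0.07 log units; within the scatter) is also small. Compound 4 is therefore estimated at 950 nM in this assay. Compound 4 is expected to fall between 500 nM and 1900 nM.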

Compound 4, concentration for 50% growth inhibition: 710 nM
Compound 4: the middle estimate sits 1.3-fold (0.13 log units) above what was measured, and the stated range covers the measured number.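

In this assay the change from phenyl to 4-fluorophenyl gives a 1.6-fold lower number from compound 3 to compound 4 (0.19 log units; within the scatter) on the second core. Set beside the first core, the two steps do not differ: the same change on two cores in this assay, a 1.2-fold lower number (0.06 log units; within the scatter) from compound 1 to compound 2 and a 1.6-fold lower number (0.19 log units; within the scatter) from compound 3 to compound 4, 1.3-fold (0.13 log units) apart, within the scatter of two such steps. So the change carries across these two cores as a small step each time, but neither step can be told apart from the scatter of repeated measurements, so this shows neither a real gain in growth inhibition nor that the result would hold on a third core.

The compounds shown leave open what other groups would do in the same place on the ring, such as chloro or an amine. They also leave open whether a larger step would carry over between these cores as well.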